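The source may hold more compounds than are shown below. What is called first, only, known or untested is meant among the compounds shown, and "the series" means these compounds.

In a physicochemical assay for solubility, in phosphate buffer, measured as kinetic solubility, at pH 1, tested at 200 uM (on this read-out higher numbers stand for higher solubility and lower numbers for lower solubility), compound 1 `Cc1c(-c2ccnc(-c3ccc(OC(F)(F)F)cc3)c2)[nH]c2ccccc2c1=O` gives 79000 nM, compound 2 `COc1ccc2c(=O)c(C)c(-c3cncc(-c4ccc(OC(F)(F)F)cc4)c3)[nH]c2c1` gives 7800 nM, and compound 3 `COc1ccc2c(=O)c(C)c(-c3ccc(-c4ccc(OC(F)(F)F)cc4)nc3)[nH]c2c1` gives 2600 nM. Among these three numbers compound 2 stands second highest: compound 3 lies below it beyond the usual scatter, and compound 1 lies above it by a wider margin. Compound 4 `Cc1c(-c2cncc(-c3ccc(OC(F)(F)F)cc3)c2)[nH]c2ccccc2c1=O` has not yet been measured in this assay. It differs from compound 2 in one place: hydrogen in place of methoxy on an aromatic carbon. Within the data shown here, no measured pair shows this change on its own; compound 1 also lacks the methoxy group but differs from compound 2 elsewhere as well, so its higher number is only a hint. A modest rise is expected, and the step of a 1.9-fold higher number from compound 2 to compound 4 (0.28 log units; within the scatter) is an estimate, not a measurement. Compound 4 is expected to give 15000 nM, within a range from 5000 nM to 45000 nM.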

Compound 4, solubility: 140000 nM
Compound 4: middle estimate off by 9.3-fold (0.97 log units), on the low side, outside the stated range (above it).
By their numbers in this assay, from the lowest: compound 3; then compound 2; then compounds 1 and 4 (each within the scatter of the next).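

In this assay hydrogen in place of methoxy on this aromatic carbon gives an 18-fold higher number from compound 2 to compound 4 (1.25 log units; beyond the scatter) and so stands as a large change at this position. The earlier compounds shown here offered only a hint, since compound 1 also differs from compound 2 elsewhere. Nothing measured here explains the size of this step.

On these data alone, whether a fluorine atom, an ethoxy group or an amine on the same carbon would land nearer compound 2 or compound 4 remains open. Also open, as far as these compounds go, is whether removing the methoxy group from compound 3 would bring a step of similar size.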